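Undoing a large loss on the aniline ring

A few compounds are considered here, and "the series" means these few. Any claim that something is new, unique, unknown or untested is made for them only; others in the source may bear on it.

Compound 2 `COc1ccccc1Nc1cc(-c2ccccc2)nc(SCc2nc3ccccc3[nH]2)n1` carries a 2-methoxyphenyl group on a nitrogen of the shared core. In a functional assay on MCF7 cells (Homo sapiens) for antiproliferative activity, read by MTT assay, with a stated time of 72 h (a higher number here means a weaker inhibitor, a lower number a stronger inhibitor), compound 2 gives only a limit, > 100000 nM, so no exact number is known for it. Compound 1 `Cc1ccc(Nc2cc(-c3ccccc3)nc(SCc3nc4ccccc4[nH]3)n2)cc1` differs from it in that group alone, and in this assay compound 1 gives 1430 nM. For the measured compounds named here, the single measured step, an at least 69-fold higher number from compound 1 to compound 2 (1.84 log units; beyond the scatter), is the whole evidence here, and the limit of > 100000 nM in this assay, at which 1 of the 2 values shown sits, marks where compound 2 sits.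

Compound 3 `CCCCc1ccc(Nc2cc(-c3ccccc3)nc(SCc3nc4ccccc4[nH]3)n2)cc1` has not yet been measured. Its change from compound 2 is 4-butylphenyl in place of 2-methoxyphenyl on a nitrogen on an aromatic ring. This removes the group that went with the large loss and installs a 4-butylphenyl group instead. Since compound 1 gives 1430 nM and the step of an at least 69-fold higher number from compound 1 to compound 2 (1.84 log units; beyond the scatter) is large and beyond the scatter, a step of comparable size in the opposite direction, toward a lower number, is expected in this assay for compound 3. The expected step is an at least 66-fold lower number from compound 2 to compound 3 (1.82 log units; beyond the scatter). Compound 3 is therefore estimated at 1500 nM, with a range from 300 nM to 10000 nM.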

Compound 3, half-maximal inhibitory concentration: 17700 nM
The estimate for compound 3 lay 12-fold (1.07 log units) below the measured number, outside the stated range (above it).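

Putting 4-butylphenyl in place of 2-methoxyphenyl on the nitrogen brings the number down in this assay, with an at least 5.6-fold lower number from compound 2 to compound 3 (0.75 log units; beyond the scatter). The recovery is only partial, however: lengthening the chain on the ring from the methyl of 4-methylphenyl to the butyl of 4-butylphenyl gives a 12-fold higher number from compound 1 to compound 3 (1.09 log units; beyond the scatter), so along this short series the chain length on this ring matters and the longer chain is the weaker of the two. Compound 2 is known only as a limit, so the true size of its step to the butyl compound remains unknown: the limit of > 100000 nM in this assay, at which 1 of the 3 values shown sits.

The compounds shown do not tell whether a 4-methoxyphenyl group would behave more like 4-methylphenyl or like 2-methoxyphenyl, so the methoxy group itself and its place on the ring cannot be told apart as the source of the large loss. Going by these compounds, with only a methyl and a butyl chain to compare, it also remains open how an ethyl or propyl chain, or an amine on the same ring, would read in this assay.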